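A few compounds are considered here, and "the series" means these few. Any claim that something is new, unique, unknown or untested is made for them only; others in the source may bear on it.

Of the compounds shown here, three of one series have so far been measured in a functional assay on CHO cells with Melanocortin receptor 4 (Homo sapiens) as the target, read by cAMP accumulation; on this read-out higher numbers stand for larger maximal responses and lower numbers for smaller maximal responses. Compound 1, `CC(C)[C@H](NC(=O)CCN(C)C)c1cccc(F)c1N1CCN(C(=O)[C@@H]2CN(C(C)C)C[C@H]2c2ccc(C(F)(F)F)c(F)c2)CC1`, gives 47% in this assay. Compound 2, `CNCC(=O)N[C@H](c1cc(C)ccc1N1CCN(C(=O)[C@@H]2CN(C3CCOCC3)C[C@H]2c2ccc(Cl)cc2)CC1)C(C)C`, gives 84% in this assay. Compound 3, `Cc1ccc(N2CCN(C(=O)[C@@H]3CN(C4CCOCC4)C[C@H]3c3ccc(Cl)cc3)CC2)c([C@@H](NC(=O)[C@H](C)N)C(C)C)c1`, gives 38% in this assay. On these numbers compound 1 stands second of three: its value and that of compound 3 lie within the usual scatter of each other, while compound 2 reaches a number beyond the scatter above compound 1.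

Among the measured compounds shown here, the one step recorded between close neighbours is a number 46 percentage points lower from compound 2 to compound 3 (beyond the scatter), where 1-aminoethyl replaces (methylamino)methyl on a carbonyl carbon. That change sits in a different part of the shared core and tells nothing about the aryl group on the five-membered ring.

Compound 4, `CC(C)[C@H](NC(=O)CCN(C)C)c1cccc(F)c1N1CCN(C(=O)[C@@H]2CN(C(C)C)C[C@H]2c2ccc(F)c(Cl)c2)CC1`, differs from compound 1 in one place: 3-chloro-4-fluorophenyl in place of 3-fluoro-4-(trifluoromethyl)phenyl on a saturated ring carbon. For the measured compounds named here, no measured pair varies this saturated ring carbon, so no recorded step bears on the change, and the only anchor is the value of compound 1 itself. The step expected from this change, no change at the digits printed from compound 1 to compound 4 (within the scatter), is therefore none beyond the scatter, with a wide margin to allow for the unknown. Compound 4 is estimated at 47%, within a range from 25% to 70%.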

Compound 4, intrinsic activity: the largest response reached, in percent of the reference agonist's: 78%
The estimate for compound 4 lay 31 percentage points below the measured number, and the stated range ends below it.
By their numbers in this assay, from the lowest: compounds 3 and 1 (each within the scatter of the next); then compounds 4 and 2 (each within the scatter of the next).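

Among the compounds shown here, the aryl group on the saturated ring carbon, which no earlier pair had varied, proves able to move the maximal response in this assay: 3-chloro-4-fluorophenyl in place of 3-fluoro-4-(trifluoromethyl)phenyl gives a number 31 percentage points higher from compound 1 to compound 4 (beyond the scatter). The entering group has fewer heavy atoms than the one that leaves, and neither carries a hydrogen-bond donor, a hydrogen-bond acceptor or a net charge, so the step arises between two substituted phenyl groups that match on those counts. Nothing available here accounts for the difference between these two aryl groups.

The two groups differ in more than one substituent, and the compounds shown do not separate the effect of the chlorine from that of the trifluoromethyl. Also open, from the compounds shown here alone, is how a plain phenyl or a pyridyl ring would read at this saturated ring carbon on the core of compound 1, and whether the step would hold with another group on the ring nitrogen in place of isopropyl.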